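One Amide Substituent Swap in an Antiproliferative Series

The source may hold more compounds than are shown below. What is called first, only, known or untested is meant among the compounds shown, and "the series" means these compounds.

- compound 1 `CCn1c(C(=O)NCC#N)ccc1C(CC)(CC)c1ccc(OCCC(O)(CC)CC)c(C)c1` gives 17800 nM
- compound 2 `CCOC(=O)C(CC(=O)OC)NC(=O)c1ccc(C(CC)(CC)c2ccc(OCCC(O)(CC)CC)c(C)c2)n1CC` gives 5840 nM
- compound 3 `CCn1c(C(=O)NC(CC(=O)O)C(=O)OC)ccc1C(CC)(CC)c1ccc(OCCC(O)(CC)CC)c(C)c1` gives 11200 nM

All three values come from a functional assay on PC-3 cells (Homo sapiens) for antiproliferative activity, read by MTT assay, with a stated time of 48 h (on this read-out lower numbers stand for stronger inhibition and higher numbers for weaker inhibition), and the three compounds differ only in the group on an amide-type nitrogen. The value of compound 3 11200 nM cannot be separated from either of the other two. The data show a 1.6-fold lower number from compound 1 to compound 3 (0.20 log units; within the scatter) and also a 1.9-fold higher number from compound 2 to compound 3 (0.28 log units; within the scatter) and neither step leaves the usual scatter of repeated measurements.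

The next compound is compound 4 `CCn1c(C(=O)NC(C)CO)ccc1C(CC)(CC)c1ccc(OCCC(O)(CC)CC)c(C)c1` which keeps the shared core. Its change is a group of 4 heavy atoms (3 carbon, 1 oxygen; no ring) in place of a group of 9 heavy atoms (5 carbon, 4 oxygen; no ring), on an amide-type nitrogen and the entering group is 1-(hydroxymethyl)ethyl. Among the measured compounds shown here, no measured compound carries this group, so the evidence is indirect. Three different groups at this nitrogen have been compared, and the widest gap among them, a 3.0-fold lower number from compound 1 to compound 2 (0.48 log units; beyond the scatter) in this assay is only modest. On that basis, no step beyond the scatter is expected here. The expected step is a 1.0-fold lower number from compound 3 to compound 4 (0.01 log units; within the scatter) according to this estimate. For compound 4 the estimated value is 11000 nM with an expected range from 4500 nM to 27000 nM as its likely span.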

Compound 4, half-maximal inhibitory concentration: 7870 nM
Compound 4: middle estimate off by 1.4-fold (0.15 log units), on the high side; measured number inside the range.
By their numbers in this assay, from the lowest: compounds 2, 4, 3 and 1 (each within the scatter of the next, the first and the last beyond it).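

In this assay, the change to 1-(hydroxymethyl)ethyl gives a 1.4-fold lower number from compound 3 to compound 4 (0.15 log units; within the scatter), and the comparison with the largest group gives a 1.3-fold higher number from compound 2 to compound 4 (0.13 log units; within the scatter), so compound 4 cannot be separated from either compound despite carrying a group of only 4 heavy atoms. Against cyanomethyl, the same group gives a 2.3-fold lower number from compound 1 to compound 4 (0.35 log units; beyond the scatter), which makes compound 4 the second compound shown, after compound 2, to stand apart from compound 1, while compound 3 goes against any general rule by staying within the scatter of compound 1. At this amide-type nitrogen, then, a group of 4 heavy atoms and the largest group cannot be told apart, so the number of heavy atoms alone does not sort these compounds.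

Nothing shown here gives a reason for any of these steps. Still open, on these data alone, is whether an amine or a phenyl ring on this nitrogen would stand apart from compound 2 beyond the scatter, and whether a longer chain ending in a hydroxyl would stay level with compound 4.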